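The source may report more compounds than this note shows. Statements on the series, on what has been measured and on what is new or still open speak of the compounds shown alone.

Compound 1, `COc1ccc(-c2cnc3nc(N)nc(N4CCN(c5cc(Cl)cc(Cl)c5)CC4)c3n2)cc1OC`, gives the lowest of the two numbers measured here: in a functional assay on cells (T-cell, Homo sapiens) for inhibition (a higher number here means a weaker inhibitor, a lower number a stronger inhibitor), compound 1 gives 3400 nM. Compound 2, `COc1ccc(-c2cnc3nc(N)nc(NCc4ccccc4)c3n2)cc1OC`, is the nearest neighbour on the numbers; in this assay compound 2 gives 13000 nM, a higher number that lies beyond the usual scatter, so compound 1 is the stronger of the two.

Compound 3, `COc1ccc(-c2cnc3nc(N)nc(N4CCN(C(=O)Nc5ccc(C#N)cc5)CC4)c3n2)cc1OC`, has not yet been measured. It differs from compound 1 in one place: (4-cyanophenyl)carbamoyl in place of 3,5-dichlorophenyl on an amine nitrogen in a ring. No pair of measured compounds differs in this way, so the size of this step has no precedent among the numbers shown. For the measured compounds named here, with only two measured compounds to lean on, the expectation for this change is a modest move toward a higher number, of a size that may or may not exceed the scatter: the step from a 1.6-fold higher number from compound 1 to compound 3 (0.21 log units; within the scatter) is what the estimate implies. Compound 3 is accordingly expected to give about 5500 nM in this assay, with a range from 1500 nM to 20000 nM.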

Compound 3, half-maximal inhibitory concentration: 74 nM
Estimate against measurement, compound 3: 74-fold (1.87 log units) above; measured number below the stated range.
By their numbers in this assay, from the lowest: compound 3; then compound 1; then compound 2.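

In this assay, putting (4-cyanophenyl)carbamoyl in place of 3,5-dichlorophenyl on the amine nitrogen in the ring gives a 46-fold lower number from compound 1 to compound 3 (1.66 log units; beyond the scatter) and so makes compound 3 the strongest of the three compounds. This shows that a change at this one position, with the rest of the molecule unchanged, can move the number far beyond the scatter, which the two earlier compounds could not show because they differ from each other by more than a single step at this nitrogen. Nothing measured here bears on why the number falls so far.

As far as these compounds go, the step swaps the aryl group and adds the carbamoyl link at once, so the share of each remains open. A phenylcarbamoyl without the nitrile, or a 4-cyanophenyl group attached directly to the ring nitrogen, would separate the two.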